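Adding a methyl to the indole-type ring of compound 1

The compounds below may be only part of what the source reports. "The series", "measured", "known", "first", "only" and "open" are said of these compounds alone.

Compound 1 `COc1ccc(Cl)c(-c2nnc3sc(Cc4c[nH]c5ccc(OC)cc45)nn23)c1` is the lower of the two measured numbers in a functional assay on the whole organism (strain Wistar Albino) for inhibition, with Rattus norvegicus as the target, read by paw edema, with a stated time of 3 h, at a dose of 20 mg/kg; on this read-out higher numbers stand for more inhibition at the one dose given (going by the name of the read-out) and lower numbers for less inhibition: compound 1 gives 21.4%, while compound 2 `COc1ccc2[nH]cc(Cc3nn4c(-c5ccoc5C)nnc4s3)c2c1` gives 26.1%, and the step of a number 4.7 percentage points higher from compound 1 to compound 2 (within the scatter) lies within the scatter. Compound 3 `COc1ccc(Cl)c(-c2nnc3sc(Cc4c(C)[nH]c5ccc(OC)cc45)nn23)c1` differs from compound 1 by methyl in place of hydrogen on an aromatic carbon. For the measured compounds named here, no measured step concerns this change; the only step at hand alters a different part of the molecule and is itself within the scatter. A step beyond the scatter is therefore not expected in this assay, and the estimated step is a number 1.6 percentage points higher from compound 1 to compound 3 (within the scatter). Compound 3 is expected to give about 23%, within 12% to 34%.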

Compound 3, a percentage reported as inhibition, in the whole organism at one dose (the size of the read-out at that dose, not a potency): 26.1%
Estimate against measurement, compound 3: 3.1 percentage points below, and the stated range covers the measured number.
By their numbers in this assay, from the lowest: compounds 1, 2 and 3 (each within the scatter of the next).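

In this assay, methyl in place of hydrogen on this aromatic carbon, next to the ring nitrogen, gives a number 4.7 percentage points higher from compound 1 to compound 3 (within the scatter) and so does not move the read-out beyond the scatter. For the compounds shown here, this is the first view of the five-membered aromatic ring with 1 nitrogen, where the earlier step concerned only the other end of the molecule. Nothing measured here speaks to why the number stays so.

From the compounds shown here alone, whether an ethyl, an amine or a carboxylic acid on this carbon would give a step beyond the scatter remains open.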